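The compounds below may be only part of what the source reports. "The series", "measured", "known", "first", "only" and "open" are said of these compounds alone.

Measured values in a functional assay on A375P cells (Homo sapiens) for antiproliferative activity, read by MTT assay, with a stated time of 48 h; on this read-out lower numbers stand for stronger inhibition and higher numbers for weaker inhibition:
compound 1 `Nc1cccc2c(-c3cccc(NC(=O)c4cccc(C(F)(F)F)c4)c3)ccnc12`: 7900 nM
compound 3 `Nc1cccc2c(-c3cccc(NC(=O)c4cc(Cl)cc(C(F)(F)F)c4)c3)ccnc12`: 18500 nM
compound 2 `Nc1cccc2c(-c3cccc(NC(=O)c4ccc(C(F)(F)F)cc4C(F)(F)F)c3)ccnc12`: a limit only, > 20000 nM

For the measured compounds named here, compound 3 holds the highest of the two real numbers in this assay; its nearest neighbour is compound 1, and the only single-point step measured so far is a 2.3-fold higher number from compound 1 to compound 3 (0.37 log units; beyond the scatter), chloro in place of hydrogen on an aromatic carbon. Compound 2 is not a number but a limit, (the limit of > 20000 nM in this assay, at which 1 of the 3 values shown sits).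

Compound 4 `Nc1cccc2c(-c3cccc(NC(=O)c4cc(C(F)(F)F)cc(C(F)(F)F)c4)c3)ccnc12` differs from compound 3 by trifluoromethyl in place of chloro on an aromatic carbon. The step that bears on it is a 2.3-fold higher number from compound 1 to compound 3 (0.37 log units; beyond the scatter): adding a group on that ring cost potency, and the size was modest. Compound 2, which carries two trifluoromethyl groups on the same ring, sits only at the limit, so a second trifluoromethyl group gives no sign of recovering activity. The change from chloro to trifluoromethyl is therefore expected to move compound 4 upward by a small amount, a 1.3-fold higher number from compound 3 to compound 4 (0.11 log units; within the scatter), at or just beyond the scatter, with a fair chance that this assay again reports only a limit.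

Compound 4 is expected at 24000 nM in this assay, within 9000 nM to 60000 nM.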

Compound 4, half-maximal inhibitory concentration: 3400 nM
For compound 4 the middle estimate is 7.1-fold (0.85 log units) above the measured one, and the stated range ends above it.
By their numbers in this assay, from the lowest: compound 4; then compound 1; then compound 3. At a limit, above all of these: compound 2.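

In this assay, this aromatic carbon, meta to a large group and meta to a trifluoromethyl group, does not respond to substitution in a single direction: chloro in place of hydrogen gives a 2.3-fold higher number from compound 1 to compound 3 (0.37 log units; beyond the scatter), whereas trifluoromethyl in place of hydrogen gives a 2.3-fold lower number from compound 1 to compound 4 (0.37 log units; beyond the scatter). The exchange of chloro for trifluoromethyl at the same carbon is the largest of the three steps, a 5.4-fold lower number from compound 3 to compound 4 (0.74 log units; beyond the scatter), so the loss seen with chloro cannot be read as a general penalty for any group at this position. Compound 2 is a limit and not a number, so no step to it can be read: the limit of > 20000 nM in this assay, at which 1 of the 4 values shown sits.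

On these data alone, with only hydrogen, chloro and trifluoromethyl compared at this carbon, it remains open whether trifluoromethyl is an isolated favourable case or part of a wider trend that a nitrile, a methoxy group, an amine or a carboxylic acid at the same carbon would help to define. It also remains open whether the order of compound 4, compound 1 and compound 3 holds in cell lines other than the one shown here.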